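The source may report more compounds than this note shows. Statements on the series, on what has been measured and on what is new or still open speak of the compounds shown alone.

Measured so far:
Compound 1 `COc1ccc(C(=O)/C=C/c2cc(OC)c(OC)cc2OC)cc1`: 2.18 ug/mL
Compound 2 `COc1cc(OC)c(-c2cc(=O)c3ccc(O)cc3o2)cc1OC`: 2.15 ug/mL

In a functional assay on cells (Erythrocyte, Rattus norvegicus) for inhibition, read by hemolysis, with a stated time of 1 h (on this read-out lower numbers stand for stronger inhibition and higher numbers for weaker inhibition), compound 1 gives 2.18 ug/mL and compound 2 gives 2.15 ug/mL, so the two stand within the scatter of each other and neither can be ranked above the other. Compound 3 `COc1cc(OC)c(OC)cc1/C=C/C(=O)c1ccc(-c2c[nH]cn2)cc1` has not yet been measured. It keeps the core of compound 1 but carries 1H-imidazol-4-yl in place of methoxy on an aromatic carbon, para to a large group: 1H-imidazol-4-yl in place of methoxy on an aromatic carbon. Among the compounds with values here, no measured pair of compounds shows what this exchange does in this assay, so the data offer no direction, and no shift beyond the scatter is expected. The estimated change is a 1.1-fold lower number from compound 1 to compound 3 (0.04 log units; within the scatter). For compound 3 the expected value is 2 ug/mL, with an estimated range from 0.7 ug/mL to 6 ug/mL.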

Compound 3, half-maximal inhibitory concentration: 2.48 ug/mL
Compound 3: middle estimate off by 1.2-fold (0.09 log units), on the low side; the range from low to high includes it.
By their numbers in this assay, from the lowest: compounds 2, 1 and 3 (each within the scatter of the next).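

In this assay, placing 1H-imidazol-4-yl in place of methoxy on an aromatic carbon, para to a large group, gives a 1.1-fold higher number from compound 1 to compound 3 (0.06 log units; within the scatter) and so stays within the scatter. Within the data shown here, this is the first step read at this position, as the earlier compounds formed no pair differing in one place: a five-membered aromatic ring with a hydrogen-bond donor can stand here without a shift beyond the scatter in this read-out. No measurement at hand bears on why the number holds.

On these data alone, it remains open whether another group at this position, such as an amine, a carboxylic acid or a longer alkoxy chain, would move the number beyond the scatter. A single step also leaves open whether the same holds for the methoxy groups on the other ring of compound 1.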